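This account rests on a few compounds, and the source may have more. Where it says the series, first, only, none or still open, it means among the compounds named here.

Compound 1 `CCC1(OC(=O)N2CCC(Oc3ncnc(Oc4ccc(S(C)(=O)=O)nc4C)c3F)CC2)CC1`: 83%
Compound 2 `Cc1nc(S(C)(=O)=O)ccc1Oc1ncnc(OC2CCN(C(=O)SC3CCC3)CC2)c1F`: 81%

Among the compounds with values here, in a functional assay on isolated protein for inhibition of Glucose-dependent insulinotropic receptor (Rattus norvegicus), read by HTRF and cAMP accumulation (on this read-out lower numbers stand for smaller maximal responses and higher numbers for larger maximal responses), compound 2 gives 81%, the lower of the two numbers measured so far; its nearest neighbour is compound 1, and the step of a number 2 percentage points lower from compound 1 to compound 2 (within the scatter) stays within the scatter. Compound 3 `Cc1nc(S(C)(=O)=O)ccc1Oc1ncnc(OC2CCN(C(=O)c3noc(C(C)C)n3)CC2)c1F` has not yet been measured. It differs from compound 2 by 5-isopropyl-1,2,4-oxadiazol-3-yl in place of cyclobutylsulfanyl on a carbonyl carbon. Within the data shown here, the only measured step that bears on this change is the earlier exchange at the same carbonyl carbon, a number 2 percentage points lower from compound 1 to compound 2 (within the scatter), which replaced one non-aromatic ring-bearing group by another without moving the maximal response. The new group is of a different kind, a five-membered aromatic ring with three hetero atoms, so the guidance is loose. Compound 3 is therefore expected to show a step of a number 1 percentage points lower from compound 2 to compound 3 (within the scatter), not beyond the scatter, and its maximal response is estimated at 80%, between 65% and 92%.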

Compound 3, largest response reached (reported as efficacy), in percent of the reference or control that the assay uses: 81%
For compound 3 the middle estimate is 1 percentage points below the measured one, within the range that was stated.
By their numbers in this assay, from the lowest: compounds 2, 3 and 1 (each within the scatter of the next).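

In this assay the carbonyl carbon on the amide-type nitrogen in a ring now bears 5-isopropyl-1,2,4-oxadiazol-3-yl, a five-membered aromatic ring with 3 hetero atoms, and the result reads no change at the digits printed from compound 2 to compound 3 (within the scatter) and a number 2 percentage points lower from compound 1 to compound 3 (within the scatter). Compound 1 and compound 2 had shown this only for groups with a non-aromatic ring of carbon only, whereas compound 3 extends it to an aromatic ring, so all three compounds lie within the scatter of one another whichever of these groups stands at this place. Nothing measured here gives a reason for this result.

From the compounds shown here alone, it remains open whether a group of another kind on the same carbonyl carbon, such as a dimethylamino group or a ring bearing a carboxylic acid, would also give a number within the scatter of these three. Going by these compounds, it is equally open whether a longer chain, such as n-butyl, could stand in place of the isopropyl on the oxadiazole without leaving that range.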